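The compounds below may be only part of what the source reports. "The series", "measured", "known", "first", "only" and "open" are said of these compounds alone.

Working notes on the series.

Of the compounds shown here, two of this set have been measured in a functional assay on SW-620 cells (Homo sapiens) for cytotoxicity, read by sulforhodamine B assay, with a stated time of 48 h; a higher number here means that more compound is tolerated, a lower number that less compound is tolerated. Compound 1 `Nc1nc(Cl)c2ncn(Cc3ccc(CCl)cc3)c2n1` gives 87100 nM in this assay. Compound 2 `ClCc1ccccc1Cn1cnc2nc(Cl)nc(Cl)c21` gives 4670 nM in this assay, which is the lower of the two numbers; the gap between compound 2 and compound 1 lies beyond the usual scatter of repeated runs, so compound 2 is the one of which less is tolerated by the cells. For the measured compounds named here, no pair of measured compounds differs in only one place, so no single-change step is available to calibrate the next move.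

Compound 3 `ClCc1ccccc1Cn1cnc2ncnc(Cl)c21` has not yet been measured in this assay. Relative to compound 2 the change is hydrogen in place of chloro on an aromatic carbon. With no measured step of this kind in the series, the expectation rests on the value of compound 2 alone. The step from compound 2 to compound 3 is expected to be modest and towards a higher number, a 1.9-fold higher number from compound 2 to compound 3 (0.28 log units; within the scatter), though a result within the scatter would not be surprising. Compound 3 is therefore estimated at 9000 nM in this assay, with a range from 3000 nM to 30000 nM.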

Compound 3, concentration lethal to 50% of the cells: 10000 nM
Estimate against measurement, compound 3: 1.1-fold (0.05 log units) below; the range from low to high includes it.
By their numbers in this assay, from the lowest: compound 2; then compound 3; then compound 1.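

In this assay the series now has its first single-change step: hydrogen in place of chloro gives a 2.1-fold higher number from compound 2 to compound 3 (0.33 log units; beyond the scatter) and this modest step lies beyond the usual scatter, though not by much. It shows that the aromatic carbon between two ring nitrogen atoms is a place where the substituent can shift the number, with the chloro compound being the one of which less is tolerated, while compound 3 still keeps its chloro group elsewhere on the ring and remains in the same general range as compound 2. This is one step on one pair of compounds, and nothing measured here bears on why the number moves.

The compounds shown leave open how a methoxy or fluoro group on this same carbon would compare with chloro and hydrogen, since compound 1 differs from compound 2 and compound 3 in more than one place and cannot settle the matter. Also open, on these data alone, is what happens to the number when the chloromethyl group of compound 3 gives way to a plain methyl or a hydroxymethyl group.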